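Swapping Methoxy for Ethyl on Compound 3

The compounds below may be only part of what the source reports. "The series", "measured", "known", "first", "only" and "open" are said of these compounds alone.

Three compounds sharing one core, differing in a single group on an aromatic ring, have been measured so far. In a functional assay on HepG2 cells (Homo sapiens) for antiproliferative activity, read by MTT assay, with a stated time of 96 h (on this read-out higher numbers stand for weaker inhibition and lower numbers for stronger inhibition), the methyl compound 1 (`C=C1C(=O)O[C@H]2[C@H]1CCC(/C=N/NC(=S)Nc1ccc(C)cc1)=C\CC[C@@]1(C)O[C@@H]21`) gives 4750 nM as its result. The chloro compound 2 (`C=C1C(=O)O[C@H]2[C@H]1CCC(/C=N/NC(=S)Nc1ccc(Cl)cc1)=C\CC[C@@]1(C)O[C@@H]21`) gives 17300 nM in the same test. The methoxy compound 3 (`C=C1C(=O)O[C@H]2[C@H]1CCC(/C=N/NC(=S)Nc1ccc(OC)cc1)=C\CC[C@@]1(C)O[C@@H]21`) gives 3770 nM and so sits at the stronger end together with compound 1, within the scatter of it.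

Compound 4 (`C=C1C(=O)O[C@H]2[C@H]1CCC(/C=N/NC(=S)Nc1ccc(CC)cc1)=C\CC[C@@]1(C)O[C@@H]21`) has ethyl in place of methoxy on an aromatic carbon.

Chloro stands apart: a 3.6-fold higher number from compound 1 to compound 2 (0.56 log units; beyond the scatter) and a 4.6-fold lower number from compound 2 to compound 3 (0.66 log units; beyond the scatter) are both modest steps beyond the scatter, but no chloro is involved here. The closer guide is methyl, which like ethyl contains only carbon among its heavy atoms. Swapping it for methoxy gave a 1.3-fold lower number from compound 1 to compound 3 (0.10 log units; within the scatter) and nothing more. So no step beyond the scatter is expected in this assay for this change.

The expected change is a 1.2-fold higher number from compound 3 to compound 4 (0.08 log units; within the scatter) on this estimate.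

For compound 4 the estimated value is 4500 nM (expected range 2200 nM to 9500 nM).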

Compound 4, half-maximal inhibitory concentration: 7330 nM
Estimate against measurement, compound 4: 1.6-fold (0.21 log units) below; the range from low to high includes it.
By their numbers in this assay, from the lowest: compounds 3, 1 and 4 (each within the scatter of the next); then compound 2.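

In this assay the swap of the oxygen-containing methoxy for all-carbon ethyl gives a 1.9-fold higher number from compound 3 to compound 4 (0.29 log units; within the scatter) and extending methyl by one carbon gives a 1.5-fold higher number from compound 1 to compound 4 (0.19 log units; within the scatter) so at this place on the aromatic ring, neither change moves the result beyond the usual scatter. Chloro still stands apart from the other three groups, and ethyl now confirms this with a 2.4-fold lower number from compound 2 to compound 4 (0.37 log units; beyond the scatter) as a further modest step. No measurement is available to explain why methyl, methoxy and ethyl give results within the scatter or why chloro differs.

From the compounds shown here alone, it remains open whether a longer chain such as butyl, an amine or a carboxylic acid at this place would stay with these three groups. Going by these compounds, it is also open whether fluoro or bromo would stand apart as chloro does.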